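The compounds below may be only part of what the source reports. "The series", "measured", "known", "first", "only" and "open" are said of these compounds alone.

Measured in a functional assay on A-375 cells (Homo sapiens) for antiproliferative activity, read by MTT assay, with a stated time of 24 h, tested at 0.02 ug/mL; a higher number here means a stronger effect of the compound at the concentration tested, a lower number a weaker effect:
compound 1 `CCc1ccc2nc(C(=O)Nc3c(F)cc(-c4cccc(F)c4)cc3F)c(C)c(O)c2c1` gives -0.12%
compound 2 `CCOc1ccc2nc(C(=O)Nc3c(F)cc(-c4cccc(F)c4)cc3F)c(C)c(O)c2c1` gives 0.68%
compound 3 `CCc1ccc2nc(C(=O)Nc3c(F)cc(-c4cccc(F)c4)cc3F)c(C)c(C(=O)O)c2c1` gives -0.12%

Compound 3 stands level with compound 1 at the digits printed, and the two are together the lowest of the three numbers; the furthest of the three from compound 3 lies a number 0.8 percentage points higher from compound 1 to compound 2 (within the scatter), still within the scatter. The move no change at the digits printed from compound 1 to compound 3 (within the scatter) likewise leaves the read-out where it was.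

Compound 4 `CCOc1ccc2nc(C(=O)Nc3c(F)cc(-c4cccc(F)c4)cc3F)c(C)c(C(=O)O)c2c1` has not been measured. It differs from compound 3 in one place: ethoxy in place of ethyl on an aromatic carbon. Among the compounds with values here, one measured step bears on this exchange, made on the hydroxy pair: a number 0.8 percentage points higher from compound 1 to compound 2 (within the scatter), within the scatter. Within the data shown here, no other step in the set informs it. For compound 4, therefore, a step of about that size is expected in this assay, in neither direction beyond the scatter: a number 0.8 percentage points higher from compound 3 to compound 4 (within the scatter).

Compound 4 is thus estimated at 0.7%, with an expected range from -5% to 6%.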

Compound 4, a percentage reported as inhibition, at one concentration (the size of the read-out at that concentration, not a potency): 1.02%
Compound 4: middle estimate off by 0.3 percentage points, on the low side, and the stated range covers the measured number.
By their numbers in this assay, from the lowest: compounds 1, 3, 2 and 4 (each within the scatter of the next).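

In this assay, ethoxy in place of ethyl now reads on the carboxy core as well as the hydroxy core, as a number 1.1 percentage points higher from compound 3 to compound 4 (within the scatter), and carboxy in place of hydroxy reads on the ethoxy core as well as the ethyl core, as a number 0.3 percentage points higher from compound 2 to compound 4 (within the scatter). The exchange of ethyl for ethoxy at this position thus behaves alike on both cores: the same change on two cores in this assay, a number 0.8 percentage points higher (within the scatter) from compound 1 to compound 2 and a number 1.1 percentage points higher (within the scatter) from compound 3 to compound 4, 0.3 percentage points apart, within the scatter of two such steps. The exchange of hydroxy for carboxy does likewise: the same change on two cores in this assay, no change at the digits printed (within the scatter) from compound 1 to compound 3 and a number 0.3 percentage points higher (within the scatter) from compound 2 to compound 4, 0.3 percentage points apart, within the scatter of two such steps.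

All four compounds give almost no inhibition at the one concentration shown, so it remains open whether either exchange would matter at a concentration where inhibition is substantial. Also open, on these data alone, is how an amine or a longer chain such as propoxy would read at this position.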